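The source may report more compounds than this note shows. Statements on the series, on what has been measured and on what is new or still open speak of the compounds shown alone.

Compound 1, `CCCCNc1nc(N)nc2cc(OC)ccc12`, switches on Toll-like receptor 8, and in an ADME assay on HEK293 cells for agonist activity at Toll-like receptor 8 (Homo sapiens), read by a luciferase reporter, with a stated time of 6 h (on this read-out lower numbers stand for an effect already at smaller amounts and higher numbers for an effect only at larger amounts of compound), compound 1 gives 0.3 uM. Compound 2, `CCCCNc1nc(N)nc2cc(OC)c(OC)cc12`, differs from compound 1 only by methoxy in place of hydrogen on an aromatic carbon, placed on an aromatic carbon of a six-membered aromatic ring of carbon only, part of a fused or bridged system of two rings, ortho to a methoxy group, meta to a fused ring and para to a fused ring. In this assay compound 2 gives 1.1 uM, so that a 3.7-fold higher number from compound 1 to compound 2 (0.56 log units; beyond the scatter).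

Compound 3, `CCCCNc1nc(N)nc2cccc(OCc3ccccc3)c12`, is built on a different core; how its core differs from that of compound 1 is not broken down here. In this assay compound 3 gives 1.66 uM, close to the number for compound 2 and well apart from that for compound 1.

Compound 4, `CCCCNc1nc(N)nc2cccc(OCc3ccccc3OC)c12`, has not yet been measured. It differs from compound 3 by methoxy in place of hydrogen on an aromatic carbon, here on an aromatic carbon of a six-membered aromatic ring of carbon only, ortho to a large group. This is the same kind of change as that from compound 1 to compound 2, but the surroundings of the place differ. Because a 3.7-fold higher number from compound 1 to compound 2 (0.56 log units; beyond the scatter) raised the number, a rise of similar size is expected for compound 4 as well. For compound 4 the expected step is a 2.4-fold higher number from compound 3 to compound 4 (0.38 log units; beyond the scatter). Compound 4 is thus expected to give 4 uM in this assay, most likely between 1.5 uM and 10 uM.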

Compound 4, minimum effective concentration: > 25 uM
Compound 4: a limit, no number; the forecaster's own chance of this, stated with the estimate: 10%; at least 6.2-fold (0.79 log units) between middle value and limit.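

In this assay, methoxy in place of hydrogen on an aromatic carbon raises the number on both cores, but the size of the step does not carry over from one core to the other: the same change on two cores in this assay, a 3.7-fold higher number (0.56 log units; beyond the scatter) from compound 1 to compound 2 and an at least 15-fold higher number (1.17 log units; beyond the scatter) from compound 3 to compound 4, at least 4.1-fold (0.61 log units) apart, beyond the scatter of two such steps. On these data alone, on the core of compound 3, the change from phenyl to 2-methoxyphenyl gives an at least 15-fold higher number from compound 3 to compound 4 (1.17 log units; beyond the scatter), and this figure is only a lower bound, so the true size of the step remains unknown. With a single pair on each core and the methoxy in different surroundings in each pair, these results do not show whether the core or the surroundings set the gap, and compound 4 stands at a limit of the assay, not at a number: the limit of > 25 uM in this assay, at which 1 of the 4 values shown sits.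

The compounds shown leave open whether a smaller group, such as fluorine or a methyl, at the same place on the phenyl ring would also raise the number this sharply. They also leave open whether methoxy at another place on that phenyl ring, or a hydroxyl in its stead, would give a number that can be read within the range of the assay.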